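Thiocarbonyl substituent change at compound 3

The source may report more compounds than this note shows. Statements on the series, on what has been measured and on what is new or still open speak of the compounds shown alone.

Measured so far in a functional assay on HCT-116 cells (Homo sapiens) for antiproliferative activity, read by CCK-8 assay, with a stated time of 72 h; on this read-out lower numbers stand for stronger inhibition and higher numbers for weaker inhibition:
- compound 1 `Nc1ccccc1NC(=O)c1ccc(CSC(=S)N2CCc3ccccc32)cc1`: 2700 nM
- compound 2 `CC1CCCCN1C(=S)SCc1ccc(C(=O)Nc2ccccc2N)cc1`: 1320 nM

Among the compounds with values here, of these two numbers, compound 2 holds the lower, and compound 1 is its only neighbour. The next compound to be read is compound 3 `CCN(Cc1ccncc1)C(=S)SCc1ccc(C(=O)Nc2ccccc2N)cc1`, which keeps the shared core of compound 2. The change is ethyl((pyridin-4-yl)methyl)amino in place of 2-methylpiperidin-1-yl on a thiocarbonyl carbon.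

Within the data shown here, only one measured step bears on this: a 2.0-fold lower number from compound 1 to compound 2 (0.31 log units; beyond the scatter), a modest step at the same thiocarbonyl carbon. It involves a different pair of groups, so it offers a scale rather than a direction. Among the measured compounds shown here, no measured compound carries ethyl((pyridin-4-yl)methyl)amino, and two values cannot show a trend. For the measured compounds named here, a step no larger than that modest one is therefore expected in this assay, leaning to a higher number, with compound 2 at 1320 nM the lower of only two values. The expected step, a 1.5-fold higher number from compound 2 to compound 3 (0.18 log units; within the scatter), may not clear the scatter. For compound 3 the estimate is 2000 nM, with an expected range of 800 nM to 5000 nM.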

Compound 3, half-maximal inhibitory concentration: 750 nM
Compound 3: middle estimate off by 2.7-fold (0.43 log units), on the high side; measured number outside the range, below it.
By their numbers in this assay, from the lowest: compounds 3 and 2 (each within the scatter of the next); then compound 1.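

In this assay the thiocarbonyl carbon tolerates a group of a different kind: ethyl((pyridin-4-yl)methyl)amino replaces the six-membered non-aromatic ring of 2-methylpiperidin-1-yl with a six-membered aromatic ring with 1 hetero atom, and the result is a 1.8-fold lower number from compound 2 to compound 3 (0.25 log units; within the scatter) and so gives no order between the two groups. Set against 2,3-dihydro-1H-indol-1-yl, the same group gives a 3.6-fold lower number from compound 1 to compound 3 (0.56 log units; beyond the scatter) at this position, so compound 1 now stands apart from both compound 2 and compound 3 by steps beyond the scatter, and compound 1 is the weakest of the three. Nothing on hand gives a reason for either step.

On these data alone, it remains open which part of ethyl((pyridin-4-yl)methyl)amino matters, as a phenyl ring in place of the pyridine ring, or a methyl or propyl chain in place of the ethyl, would be needed to separate the parts. It is equally open how ring amines such as morpholine or piperazine on the thiocarbonyl carbon would compare in this assay with the three groups shown.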